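The source may report more compounds than this note shows. Statements on the series, on what has been measured and on what is new or still open speak of the compounds shown alone.

Compound 1 `COC(=O)c1sc2cc(-c3ccoc3)cnc2c1N` gives in a functional assay on NCI-H460 cells (Homo sapiens) for inhibition, read by sulforhodamine B assay, with a stated time of 48 h (on this read-out lower numbers stand for stronger inhibition of growth and higher numbers for weaker inhibition of growth), only a limit, > 120000 nM.
Compound 2 `COC(=O)c1sc2cc(-c3ccc(C#N)cc3)cnc2c1N` gives in this assay only a limit, > 75000 nM.
Compound 3 `COC(=O)c1sc2cc(-c3ccc(C(F)(F)F)cc3)cnc2c1N` gives in this assay only a limit, > 150000 nM.

None of the three compounds therefore has a number in this assay. Compound 3 stands at the limit of > 150000 nM in this assay, at which 1 of the 3 values shown sits, and the other two values are likewise limits, the limit of > 120000 nM in this assay, at which 1 of the 3 values shown sits, and (the limit of > 75000 nM in this assay, at which 1 of the 3 values shown sits). Nothing among them can be ordered against the others.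

The next compound, compound 4 `COC(=O)c1sc2cc(-c3ccc(N)cc3)cnc2c1N`, differs from compound 3 in one place: amino in place of trifluoromethyl on an aromatic carbon. Going by the values given here, the only measured step that touches the same position is a step that the two limits leave unreadable from compound 2 to compound 3. Both of its ends are limits, and its size cannot be read. Among the compounds with values here, no measured step shows that a change at this position of the shared core moves the read-out in either direction, and no value anywhere among the three compounds reaches a number.

On that basis compound 4 is expected to stay where compound 3 stands, and the step of a number no higher from compound 3 to compound 4 (the limit leaves the size open) is estimated as none beyond the scatter. Compound 4 is estimated at 150000 nM, within a range from 40000 nM to 500000 nM, most likely reported again only as a limit.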

Compound 4, concentration for 50% growth inhibition: 37100 nM
Compound 4: the middle estimate sits 4.0-fold (0.61 log units) above what was measured, outside the stated range (below it).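

In this assay, going by these compounds alone, compound 4 is the first compound to give a number and not a limit, so a change on this aromatic carbon can move the read-out, which no earlier pair could show. Amino in place of trifluoromethyl gives an at least 4.0-fold lower number from compound 3 to compound 4 (0.60 log units; beyond the scatter) and 4-aminophenyl in place of furan-3-yl gives an at least 3.2-fold lower number from compound 1 to compound 4 (0.50 log units; beyond the scatter) and both of these floors lie beyond the scatter. Amino in place of cyano gives an at least 2.0-fold lower number from compound 2 to compound 4 (0.30 log units; that floor lies within the scatter) and that floor does not by itself separate the two compounds; each of the three steps has a limit at one end, so its full size stays open, and the step between compound 2 and compound 3 cannot be read.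

Going by these compounds, whether a methylamino group, a dimethylamino group, a hydroxyl or a carboxylic acid on the same aromatic carbon would also bring the read-out to a number stays open, as does how much of the change belongs to the amino group alone. Nothing among the values shown gives a reason why amino brings a number here.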